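A few compounds are considered here, and "the series" means these few. Any claim that something is new, unique, unknown or untested is made for them only; others in the source may bear on it.

Measured compounds:
- compound 1 `CCc1cnc(N2CCC(c3nc(COc4ccc(/C=C5\CC(=O)NC5=O)cc4F)cs3)CC2)nc1`: 49 nM
- compound 2 `CCc1cnc(N2CCC(c3nc(COc4ccc(/C=C/C(=O)O)cc4F)cs3)CC2)nc1`: "not determined" (no result reported)
- compound 3 `CCc1cnc(N2CCC(c3nc(COc4ccc(/C=C5\SC(=S)N(N)C5=O)cc4F)cs3)CC2)nc1`: "not determined" (no result reported)

Within the data shown here, in a functional assay on cells for agonist activity at Glucose-dependent insulinotropic receptor (Homo sapiens), read by a luciferase reporter, with a stated time of 6 h (on this read-out lower numbers stand for an effect already at smaller amounts and higher numbers for an effect only at larger amounts of compound), compound 1 gives 49 nM and is the only compound of this set with a number. Among the measured compounds shown here, for compound 2 the entry in this assay is "not determined" (no result reported), and for compound 3 it is "not determined" (no result reported), so neither of these two offers a value to place beside compound 1, and no step between measured compounds can be drawn from this set.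

Compound 4 `CCc1cnc(N2CCC(c3nc(COc4ccc(/C=C5\CC(=O)N(c6ccccc6)C5=O)cc4F)cs3)CC2)nc1` has not been measured. Its difference from compound 1 is phenyl in place of hydrogen on an amide-type nitrogen in a ring. The imide of compound 1 carries a hydrogen on its ring nitrogen; in compound 4 that hydrogen is replaced by phenyl while the rest of the shared core is kept.

For the measured compounds named here, no measured pair shows what such a change does here, so the expectation rests on compound 1 alone, whose value 49 nM is the only anchor. The step from compound 1 to compound 4 is expected to be a 4.1-fold higher number from compound 1 to compound 4 (0.61 log units; beyond the scatter), a loss beyond the usual scatter, though with wide uncertainty. For compound 4 the estimate in this assay is 200 nM, within a range from 40 nM to 1500 nM.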

Compound 4, half-maximal effective concentration: 82 nM
Compound 4: middle estimate off by 2.4-fold (0.39 log units), on the high side; low and high end bracket the measured number.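

In this assay, among these compounds, phenyl in place of hydrogen on the amide-type nitrogen of the five-membered non-aromatic ring comes with a 1.7-fold higher number from compound 1 to compound 4 (0.22 log units; within the scatter), the first step in this set that can be read. The two compounds are therefore not told apart by this read-out, which shows that the amide hydrogen can be replaced by this six-membered aromatic ring while agonist activity stays in the same range. Nothing available gives a reason for this result.

The entries for compound 2 and compound 3 hold no number, so steps involving them cannot be read, and the part played by the five-membered non-aromatic ring itself remains unsettled. With only hydrogen and phenyl shown on this nitrogen, it stays open whether a methyl, a benzyl or a phenyl carrying a carboxylic acid or an amine would also remain in this range, and this one pair cannot say how far the tolerance at this position extends.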